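Notes on the sulfanyl step from compound 2 to compound 3

A few compounds are considered here, and "the series" means these few. Any claim that something is new, unique, unknown or untested is made for them only; others in the source may bear on it.

Compound 1 `Cc1ccc(S(=O)(=O)/C(=C/c2c(O)cc(O)cc2O)C(=O)c2ccc(Br)cc2)cc1` gives > 100000 nM (a limit)
Compound 2 `COc1cc(OC)c(/C=C(/Sc2ccc(C)cc2)C(=O)c2ccc(Cl)cc2)c(OC)c1` gives > 100000 nM (a limit)

Both entries come from a functional assay on DU-145 cells (Homo sapiens) for inhibition, read by trypan blue exclusion, with a stated time of 96 h (a higher number here means a weaker inhibitor of growth, a lower number a stronger inhibitor of growth), and neither is a number. Compound 2 stands at the limit of > 100000 nM in this assay, at which 2 of the 2 values shown sit, alongside compound 1, so the two cannot be ordered.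

Compound 3 `COc1cc(OC)c(/C=C(/SCc2ccc(Cl)cc2Cl)C(=O)c2ccc(Cl)cc2)c(OC)c1` keeps the shared core of compound 2 and changes one group, with 2,4-dichlorobenzyl in place of 4-methylphenyl on a sulfur. In other words, (4-methylphenyl)sulfanyl becomes (2,4-dichlorobenzyl)sulfanyl. Within the data shown here, no measured pair differs in one place, so the size of this step has no direct guide in this assay.

For compound 2 the limit > 100000 nM is the only reference, and a measurable change from it can only run toward stronger inhibition of growth. A step in that direction is expected, of uncertain size, and compound 3 may well remain at a limit. The estimated change is an at least 12-fold lower number from compound 2 to compound 3 (1.09 log units; beyond the scatter). For compound 3 the estimated value is 8000 nM, with an expected range from 500 nM to 100000 nM.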

Compound 3, concentration for 50% growth inhibition: 1000 nM
The estimate for compound 3 lay 8.0-fold (0.90 log units) above the measured number, within the range that was stated.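

In this assay, the sulfur position proves able to give a measurable value: 2,4-dichlorobenzyl in place of 4-methylphenyl gives an at least 100-fold lower number from compound 2 to compound 3 (2.00 log units; beyond the scatter), and compound 3, at 1000 nM, is the only compound shown with a true number. Compound 2 gives > 100000 nM, which is a limit and not a number. The step can therefore be read only as a minimum, and its full size stays open because its starting point is a limit of the assay: the limit of > 100000 nM in this assay, at which 2 of the 3 values shown sit.

The change swaps the whole group on sulfur, so the compounds shown do not separate the contribution of the extra carbon of the benzyl group from that of the two chlorines, and a plain benzyl, a 4-chlorobenzyl or a 4-methylbenzyl group on the same sulfur would be needed to tell these apart. Also open, on these data alone, is whether the 2,4-dichlorobenzyl group would give a measurable number with other groups in the rest of the shared core, since compound 1 differs from compound 3 in more than one place and offers no comparison.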